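The source may hold more compounds than are shown below. What is called first, only, known or untested is meant among the compounds shown, and "the series" means these compounds.

Measured compounds:
Compound 1, `CNCC[C@@H]1CCO[C@H](c2ccccc2)O1`, gives 449 nM in an assay for displacement of a labelled ligand from Sigma non-opioid intracellular receptor 1 (Cavia porcellus), read by scintillation counting; on this read-out higher numbers stand for weaker inhibition and lower numbers for stronger inhibition.
Compound 2, `CC[C@@]1(c2ccccc2)OCC[C@@H](CCNC)O1`, gives 856 nM in this assay.
Compound 3, `CN(C)CCC[C@@H]1CCO[C@H](c2ccccc2)O1`, gives 1220 nM in this assay.

Compound 2 sits among the three numbers: the step of a 1.9-fold higher number from compound 1 to compound 2 (0.28 log units; within the scatter) is within the scatter, and compound 3 also lies within the scatter of compound 2. The unmeasured compound 4, `CC[C@@]1(c2ccccc2)OCC[C@@H](CCCN)O1`, keeps the same atoms as compound 2 but joins them differently: aminomethyl in place of methylamino on a saturated chain carbon, two bonds along the chain from a saturated ring carbon. Within the data shown here, only one measured step touches the amine end of the chain, a 2.7-fold higher number from compound 1 to compound 3 (0.43 log units; beyond the scatter), which read as a modest weakening. The other step, a 1.9-fold higher number from compound 1 to compound 2 (0.28 log units; within the scatter), concerns the ring carbon and says nothing about the amine. Reshaping the amine in compound 4 is therefore expected to move the number little, the step of a 1.3-fold higher number from compound 2 to compound 4 (0.11 log units; within the scatter) being around or just beyond the scatter toward a higher number. Compound 4 is estimated at 1100 nM in this assay. The expected range for compound 4 is estimated to run from 450 nM to 2700 nM.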

Compound 4, inhibition constant: 6450 nM
For compound 4 the middle estimate is 5.9-fold (0.77 log units) below the measured one, and the stated range ends below it.
By their numbers in this assay, from the lowest: compounds 1, 2 and 3 (each within the scatter of the next, the first and the last beyond it); then compound 4.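

In this assay, turning 2-(methylamino)ethyl into 3-aminopropyl gives a 7.5-fold higher number from compound 2 to compound 4 (0.88 log units; beyond the scatter). The earlier steps shown here showed only that adding to the amine end, as in a 2.7-fold higher number from compound 1 to compound 3 (0.43 log units; beyond the scatter), can weaken inhibition; this result shows that rearranging the same atoms there, with no atom gained or lost, is also enough to do so. Nothing available explains why the number rises.

Compound 4 differs from compound 2 in both the chain and the nitrogen at once, and only a 2-aminoethyl or a 3-(methylamino)propyl group on the core of compound 2 would show how much each contributes. As far as these compounds go, whether 3-aminopropyl has a similar effect on the core of compound 1, which carries hydrogen where compound 2 carries ethyl, also stays open.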